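A few compounds are considered here, and "the series" means these few. Any claim that something is new, unique, unknown or untested is made for them only; others in the source may bear on it.

Measured so far:
- compound 1 `OC[C@H]1O[C@@H](n2cnc3c(NCc4cc(F)cc(F)c4)ncnc32)C(O)C1O`: "not determined" (no result reported)
- compound 2 `COc1ccc(CNc2ncnc3c2ncn3C2OC(CO)[C@@H](O)[C@H]2O)c(O)c1`: > 166000 nM

Both entries come from a functional assay on HOS cells (Homo sapiens) for antiproliferative activity, with a stated time of 72 h; on this read-out lower numbers stand for stronger inhibition and higher numbers for weaker inhibition. For compound 1 the record reads "not determined" (no result reported), so it has no number and no place on the scale. Compound 2 gives > 166000 nM, which is a limit of the assay and not a number. Among the measured compounds shown here, the only reading available is therefore (the limit of > 166000 nM in this assay, at which 1 of the 2 values shown sits).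

The next structure is compound 3 `OC[C@H]1O[C@@H](n2cnc3c(NCc4ccccc4C(F)(F)F)ncnc32)C(O)C1O`. The change is 2-(trifluoromethyl)phenyl in place of 3,5-difluorophenyl on a saturated chain carbon bound to a nitrogen on an aromatic ring.

For the measured compounds named here, no step has been measured for a change of this kind, and a step from compound 1 cannot be sized without a number at its start. In this assay the expectation is therefore no step beyond the scatter, with neither direction favoured. Weak inhibition is expected, and this rests only on compound 2 with its limit of > 166000 nM. A limit could well be reported again. The estimated value for compound 3 is 60000 nM, with an expected range from 8000 nM to 166000 nM.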

Compound 3, half-maximal inhibitory concentration: > 166000 nM
Compound 3: a limit, no number; the forecaster's own chance of this, stated with the estimate: 50%; at least 2.7-fold (0.44 log units) between middle value and limit.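

In this assay compound 3 gives > 166000 nM, which is a limit and not a number. Among the compounds shown here, compound 1 has no number either, so no step from compound 1 to compound 3 can be read. The compounds shown leave open whether any group on the saturated chain carbon gives a measurable value, and the results so far gather at one point: the limit of > 166000 nM in this assay, at which 2 of the 3 values shown sit.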